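This account rests on a few compounds, and the source may have more. Where it says the series, first, only, none or still open, it means among the compounds named here.

Measured in a functional assay on NCI-H226 cells (Homo sapiens) for inhibition, read by sulforhodamine B assay, with a stated time of 48 h; on this read-out higher numbers stand for weaker inhibition of growth and lower numbers for stronger inhibition of growth:
Compound 1 `O=C(Nc1cccc(-n2cc(-c3ccncc3)c(-c3ccc(Cl)c(O)c3)n2)c1)Nc1cccc(C(F)(F)F)c1`: 7350 nM
Compound 2 `COc1cc(-c2nn(-c3cccc(NC(=O)Nc4cc(C(F)(F)F)cc(C(F)(F)F)c4)c3)cc2-c2ccncc2)ccc1Cl`: 1360 nM

Of these two numbers, compound 2 holds the lower one, and its gap to compound 1 lies beyond the usual scatter. Compound 1 differs from compound 2 in two places at once, so the two values cannot be split into single steps. Compound 3 `O=C(Nc1cccc(-n2cc(-c3ccncc3)c(-c3ccc(Cl)c(O)c3)n2)c1)Nc1cc(C(F)(F)F)cc(C(F)(F)F)c1` differs from compound 2 in one place only: hydrogen in place of methyl on an oxygen on an aromatic ring. Within the data shown here, no measured pair shows this change alone, so its direction in this assay is open; a modest step, or none beyond the scatter, is expected, leaning to a slight loss as a 1.6-fold higher number from compound 2 to compound 3 (0.21 log units; within the scatter). Compound 3 is therefore expected to give about 2200 nM, within 700 nM to 7000 nM.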

Compound 3, concentration for 50% growth inhibition: 1240 nM
For compound 3 the middle estimate is 1.8-fold (0.25 log units) above the measured one; the range from low to high includes it.
By their numbers in this assay, from the lowest: compounds 3 and 2 (each within the scatter of the next); then compound 1.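

In this assay, methoxy to hydroxy on the 4-chloro-3-methoxyphenyl group makes no difference beyond the scatter (a 1.1-fold lower number from compound 2 to compound 3 (0.04 log units; within the scatter)), so this oxygen can carry either methyl or hydrogen. Among these compounds, compound 3 also gives the first single step for the second trifluoromethyl, which replaces hydrogen on an aromatic carbon (a 5.9-fold lower number from compound 1 to compound 3 (0.77 log units; beyond the scatter)). No measurement here offers an explanation for either result.

Still open, as far as these compounds go, is whether an ethyl group on this oxygen, or an amine in its place, would hold the number. Also open, from the compounds shown here alone, is whether the trifluoromethyl step would be the same with methoxy instead of hydroxy.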